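This account rests on a few compounds, and the source may have more. Where it says the series, first, only, none or still open, it means among the compounds named here.

Working notes on the series. Compound 1 `CC(C(=O)NCc1ccc(C(F)(F)F)nc1NCc1ccccc1)c1ccc(NS(C)(=O)=O)c(F)c1` serves as the reference; in a functional assay on CHO-K1 cells for antagonist activity at transient receptor potential cation channel subfamily V member 1 (Homo sapiens), read by FLIPR (a lower number here means a stronger inhibitor, a higher number a weaker inhibitor), compound 1 gives 15.8 nM. Compound 2 `CC(C(=O)NCc1ccc(C(F)(F)F)nc1N1CCN(C2CCCCC2)CC1)c1ccc(NS(C)(=O)=O)c(F)c1` carries 4-cyclohexylpiperazin-1-yl in place of benzylamino on an aromatic carbon, and in this assay compound 2 gives 21.6 nM; the step of a 1.4-fold higher number from compound 1 to compound 2 (0.14 log units; within the scatter) stays within the scatter. Going by the values given here, of the two numbers so far compound 2 carries the larger figure, though the gap to compound 1 lies within the scatter and the two are not separable. Compound 3 `CC(C(=O)NCc1ccc(C(F)(F)F)nc1N1CCN(c2ncccc2C(F)(F)F)CC1)c1ccc(NS(C)(=O)=O)c(F)c1` keeps the piperazine of compound 2 and alters only the group on its ring nitrogen: 3-(trifluoromethyl)pyridin-2-yl in place of cyclohexyl on an amine nitrogen in a ring. Among the compounds with values here, no measured step touches this ring nitrogen; the single step available exchanged the whole substituent on the aromatic carbon and shifted the number little. For compound 3 a step no larger than the scatter is therefore expected, a 1.2-fold higher number from compound 2 to compound 3 (0.06 log units; within the scatter), in either direction. Compound 3 is estimated at 25 nM, range 8 nM to 80 nM.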

Compound 3, inhibition constant: 2.8 nM
Estimate against measurement, compound 3: 8.9-fold (0.95 log units) above; measured number outside the range, below it.
By their numbers in this assay, from the lowest: compound 3; then compounds 1 and 2 (each within the scatter of the next).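

In this assay, going by these compounds alone, the group on the ring nitrogen of the piperazine is a place where the number can move: 3-(trifluoromethyl)pyridin-2-yl in place of cyclohexyl gives a 7.7-fold lower number from compound 2 to compound 3 (0.89 log units; beyond the scatter), whereas the only earlier step, a 1.4-fold higher number from compound 1 to compound 2 (0.14 log units; within the scatter), stayed within the scatter. This single change replaces a non-aromatic carbon ring with an aromatic ring that has one hetero atom and one hydrogen-bond acceptor, and it also brings in a trifluoromethyl, so the step cannot be assigned to any one of these features. No measurement at hand accounts for the lower number. From the compounds shown here alone, it remains open how pyridin-2-yl alone or 3-(trifluoromethyl)phenyl on this nitrogen would read, which would separate the ring nitrogen from the trifluoromethyl. Also open, going by these compounds, is how a small group such as methyl would read at this nitrogen.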